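The source may hold more compounds than are shown below. What is called first, only, known or untested is meant among the compounds shown, and "the series" means these compounds.

Measured so far:
- compound 1 `CCOC(=O)OCC#CCSc1c(SC)cnc2ccccc12`: 34.2 ug/mL
- compound 2 `CSc1cnc2ccccc2c1SCC#CCCl`: 3.9 ug/mL

In a functional assay on T47D cells (Homo sapiens) for antiproliferative activity, with a stated time of 72 h (on this read-out higher numbers stand for weaker inhibition and lower numbers for stronger inhibition), compound 1 gives the highest of the two numbers; its nearest neighbour is compound 2, which stands an 8.8-fold lower number from compound 1 to compound 2 (0.94 log units; beyond the scatter). That step replaces the whole (ethoxycarbonyl)oxy group with chloro.

Compound 3 `CSc1cnc2ccccc2c1SCC#CCOC(=O)c1ccc(C(=O)O)cc1` keeps the shared core and the carbonyl of compound 1 but changes what sits on that carbonyl carbon: 4-carboxyphenyl in place of ethoxy on a carbonyl carbon.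

For the measured compounds named here, no measured step touches that part of the molecule. Going by the values given here, the only step available, from compound 1 to compound 2, removes the ester altogether rather than changing the group on its carbonyl carbon, so it says nothing direct about this exchange. With no guide to either direction, the number for compound 3 is expected to stay close to that of compound 1, with the step of a 1.1-fold lower number from compound 1 to compound 3 (0.06 log units; within the scatter) expected to lie within the usual scatter. Compound 3 is therefore estimated at 30 ug/mL, in a range from 10 ug/mL to 90 ug/mL.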

Compound 3, concentration for 50% inhibition: 36.1 ug/mL
For compound 3 the middle estimate is 1.2-fold (0.08 log units) below the measured one, within the range that was stated.
By their numbers in this assay, from the lowest: compound 2; then compounds 1 and 3 (each within the scatter of the next).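

On the carbonyl carbon of this ester, 4-carboxyphenyl in place of ethoxy brings a six-membered aromatic ring and a hydrogen-bond donor, yet in this assay the result is a 1.1-fold higher number from compound 1 to compound 3 (0.02 log units; within the scatter) and the two compounds read alike. The group on this carbon can therefore be either a small ethoxy or a much larger ring-bearing group with no separation in the read-out, whereas removing the ester altogether gives an 8.8-fold lower number from compound 1 to compound 2 (0.94 log units; beyond the scatter) and does go beyond the scatter. No measurement here explains why the two groups read alike.

Since this exchange adds the ring and the carboxylic acid together, a plain phenyl group on the same carbonyl carbon would be needed to tell their contributions apart. On these data alone, whether an amine or a longer chain at this place would also read alike remains open.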